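Trimming the Anilide Methyl Pattern on a Weak Indole Azo Series

The compounds below may be only part of what the source reports. "The series", "measured", "known", "first", "only" and "open" are said of these compounds alone.

Three anilides of a shared core have been tested in a functional assay on P388 cells (Mus musculus) for inhibition, read by MTT assay, with a stated time of 72 h; a higher number here means a weaker inhibitor, a lower number a stronger inhibitor. Compound 1 `O=C(Nc1ccccc1Cl)c1ccc(/N=N\c2c[nH]c3ccccc23)cc1` is reported as "not active" (no number reported) and compound 3 `COc1ccccc1NC(=O)c1ccc(/N=N\c2c[nH]c3ccccc23)cc1` as "not active" (no number reported), with no number given for either. Only compound 2 `Cc1ccc(NC(=O)c2ccc(/N=N\c3c[nH]c4ccccc34)cc2)c(C)c1` carries a value, at 190000 nM, which makes it the sole numerical reference in this set. Compound 4 `Cc1cccc(NC(=O)c2ccc(/N=N\c3c[nH]c4ccccc34)cc2)c1` differs from compound 2 by 3-methylphenyl in place of 2,4-dimethylphenyl on an amide-type nitrogen. Among the compounds with values here, with no measured pair of this kind to lean on, and with two of three neighbours of compound 2 giving no number in this assay, the step from compound 2 to compound 4 is expected to stay within the scatter or drift toward weaker inhibition, as a 1.3-fold higher number from compound 2 to compound 4 (0.12 log units; within the scatter). Compound 4 is therefore estimated at 250000 nM, in a range from 80000 nM to 800000 nM.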

Compound 4, half-maximal inhibitory concentration: 300 nM
The estimate for compound 4 lay 830-fold (2.92 log units) above the measured number, and the stated range ends above it.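

In this assay, 3-methylphenyl in place of 2,4-dimethylphenyl on the amide-type nitrogen gives a 630-fold lower number from compound 2 to compound 4 (2.80 log units; beyond the scatter). The earlier compounds shown here offered a single number and so could not show that the group on this nitrogen can move the read-out so far. Nothing at hand explains the size of this step.

Within the data shown here, the single step changes both the number of methyl groups and their pattern, so it leaves open which of the two carries the change. As far as these compounds go, how an amine or a carboxylic acid on this phenyl ring would fare also remains open.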